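This account rests on a few compounds, and the source may have more. Where it says the series, first, only, none or still open, it means among the compounds named here.

In an ADME assay on the whole organism (strain Sprague-Dawley) for pharmacokinetics, with Rattus norvegicus as the target, at a dose of 10 mg/kg by the oral route (on this read-out lower numbers stand for slow clearance and higher numbers for fast clearance), compound 1 (`COc1nc2cccnc2n1-c1ccc(Nc2ccc(C)cn2)cc1`) gives 19.5 mL/min/kg and compound 2 (`COc1nc2cccnc2n1-c1ccc(Nc2nc3ccccc3s2)cc1`) gives 10.8 mL/min/kg on the same read-out. For the measured compounds named here, these two values lie within the usual scatter of each other, so compound 1 has no clear rank against its only measured neighbour. Compound 3 (`CCCc1nc2cccnc2n1-c1ccc(Nc2ccc(C)cn2)cc1`) keeps the rest of compound 1 and carries propyl in place of methoxy on an aromatic carbon, between two ring nitrogen atoms: propyl in place of methoxy on an aromatic carbon is the whole change. Going by the values given here, the one measured step is a 1.8-fold lower number from compound 1 to compound 2 (0.26 log units; within the scatter) and it exchanges a different group, 1,3-benzothiazol-2-yl in place of 5-methylpyridin-2-yl on a nitrogen on an aromatic ring. Among the compounds with values here, no measured step touches the methoxy group, so the data give no direct guide to this change. The expectation therefore rests on compound 1 at 19.5 mL/min/kg and no step beyond the scatter is expected in this assay in either direction. The expected move is a 1.1-fold higher number from compound 1 to compound 3 (0.05 log units; within the scatter) and nothing larger is estimated. For compound 3 the estimate is 22 mL/min/kg with an expected range from 9 mL/min/kg to 50 mL/min/kg at its two ends.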

Compound 3, clearance: 34.2 mL/min/kg
For compound 3 the middle estimate is 1.6-fold (0.19 log units) below the measured one; the measured number falls inside the stated range.
By their numbers in this assay, from the lowest: compounds 2, 1 and 3 (each within the scatter of the next, the first and the last beyond it).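

In this assay, for the compounds shown here, the first measured step at this position, propyl in place of methoxy on the aromatic carbon between two ring nitrogen atoms, gives a 1.8-fold higher number from compound 1 to compound 3 (0.24 log units; within the scatter). The exchange removes the hydrogen-bond acceptor counted on methoxy and brings in a purely carbon chain, yet compound 1 and compound 3 cannot be told apart on this read-out, so this swap at this position shows no clear effect on clearance. No measurement is available that bears on the reason for this result.

On these data alone, it remains open whether any group at this position can shift clearance beyond the usual scatter, and an amine, a carboxylic acid or a longer chain on the same carbon would help to test that. It is also open whether the exchange of methoxy for propyl gives a similar result when 1,3-benzothiazol-2-yl stands on the nitrogen in place of 5-methylpyridin-2-yl, since that combination of groups does not appear among the compounds shown here.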